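The source may hold more compounds than are shown below. What is called first, only, known or untested is meant among the compounds shown, and "the series" means these compounds.

Measured so far:
- compound 1 `COc1ccccc1/C=C1\CCC/C(=C\c2cccc(OC)c2OC)C1=O`: 12000 nM
- compound 2 `COc1cccc(/C=C2\CCC/C(=C\c3cccc(O)c3)C2=O)c1OC`: 8800 nM

In a functional assay on MCF7 cells (Homo sapiens) for cytotoxicity, read by MTT assay, with a stated time of 72 h (a lower number here means a stronger inhibitor, a higher number a weaker inhibitor), compound 2 gives 8800 nM, within the scatter of compound 1. Compound 3 `COc1cccc(/C=C2\CCC/C(=C\c3ccc(Cl)cc3Cl)C2=O)c1OC` has not yet been measured. It differs from compound 2 by 2,4-dichlorophenyl in place of 3-hydroxyphenyl on a double-bonded chain carbon bound to a double-bonded ring carbon. Going by the values given here, one measured step bears on this, a swap at the same place: a 1.4-fold lower number from compound 1 to compound 2 (0.13 log units; within the scatter). On that slim evidence, the expected change is small, with no clear direction: a 1.3-fold lower number from compound 2 to compound 3 (0.10 log units; within the scatter). Compound 3 is estimated at 7000 nM, with an expected range of 2500 nM to 20000 nM.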

Compound 3, half-maximal inhibitory concentration: > 20000 nM
Compound 3: no number, only a limit; the forecaster's own chance of this, stated with the estimate: 5%; middle value at least 2.8-fold (0.45 log units) from the limit.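

Compound 3 carries a limit, not a number: the limit of > 20000 nM in this assay, at which 1 of the 3 values shown sits. Even so, this place now responds to a swap, as 2,4-dichlorophenyl in place of 3-hydroxyphenyl gives an at least 2.2-fold higher number from compound 2 to compound 3 (0.35 log units; beyond the scatter), while the earlier swap stayed within the scatter. Against 2-methoxyphenyl, the same group gives an at least 1.6-fold higher number from compound 1 to compound 3 (0.22 log units; that floor lies within the scatter), and that floor alone settles no order.

On these data alone, how far the true value of compound 3 lies past the limit remains unknown. Also open, as far as these compounds go, is whether a single chlorine, an amine or a carboxylic acid at this place would give the same result.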